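Pyridinyl Added to an Oxadiazole Ketone Inhibitor

The compounds below may be only part of what the source reports. "The series", "measured", "known", "first", "only" and "open" are said of these compounds alone.

Compound 2 `O=C(CCCCCCc1ccccc1)c1ncno1` gives the lowest number of the two measured compounds in an assay on isolated protein for inhibition of liver carboxylesterase 1 (Homo sapiens) (on this read-out higher numbers stand for weaker inhibition and lower numbers for stronger inhibition), where compound 2 gives 0.7 nM. Compound 1 `COC(=O)c1cccc(-c2nnc(C(=O)CCCCCCc3ccccc3)o2)n1`, built on a different core, gives in this assay a value of 40 nM, a higher number that lies beyond the usual scatter. Compound 3 `O=C(CCCCCCc1ccccc1)c1nc(-c2ccccn2)no1` differs from compound 2 by pyridin-2-yl in place of hydrogen on an aromatic carbon. Among the compounds with values here, no measured pair isolates this change, but compound 1, which also carries a ring on its core and gives 40 nM, suggests a step toward weaker inhibition is expected, though beyond the scatter only modestly. Compound 3 is therefore expected to give 3 nM, within 0.5 nM to 20 nM. The expected step is a 4.3-fold higher number from compound 2 to compound 3 (0.63 log units; beyond the scatter).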

Compound 3, half-maximal inhibitory concentration: 30 nM
Compound 3: middle estimate off by 10-fold (1.00 log units), on the low side; the whole stated range lies below it.
By their numbers in this assay, from the lowest: compound 2; then compounds 3 and 1 (each within the scatter of the next).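

Pyridin-2-yl in place of hydrogen on the aromatic carbon between two ring nitrogen atoms gives a 43-fold higher number from compound 2 to compound 3 (1.63 log units; beyond the scatter) in this assay. Within the data shown here, this is the first measured pair to isolate a change at this position, and it shows that the position does not take this ring without a large step toward weaker inhibition. No available measurement accounts for the size of this step. From the compounds shown here alone, whether a methyl group or an amine on this carbon would keep the number close to that of compound 2 remains open, as does whether a phenyl ring would give a step of similar size.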